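Swapping one ring group on a shared core

This account rests on a few compounds, and the source may have more. Where it says the series, first, only, none or still open, it means among the compounds named here.

Compound 1 `CC(C)C1=C(C(=O)N2[C@H](C)CC[C@H]2C(=O)N2CCN(C)CC2)SC2=N[C@@](C)(c3ccc(Cl)cc3)[C@@H](c3ccc(Cl)cc3)N21`: 9000 nM
Compound 2 `CC(=O)N1CCN(C(=O)[C@@H]2CC[C@@H](C)N2C(=O)C2=C(C(C)C)N3C(=N[C@@](C)(c4ccc(Cl)cc4)[C@H]3c3ccc(Cl)cc3)S2)CC1`: 16000 nM

Both numbers come from a functional assay on DLD-1 cells (Homo sapiens) for inhibition, read by luminescence, with a stated time of 3 days; on this read-out higher numbers stand for weaker inhibition of growth and lower numbers for stronger inhibition of growth. Compound 1 and compound 2 stand within the scatter of each other, so these numbers cannot rank the two.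

Compound 3 `CC(C)C1=C(C(=O)N2[C@H](C)CC[C@H]2C(=O)N2CCN(C)C(C)(C)C2)SC2=N[C@@](C)(c3ccc(Cl)cc3)[C@@H](c3ccc(Cl)cc3)N21` has not been measured yet. It differs from compound 1 in one place: a group of 9 heavy atoms (7 carbon, 2 nitrogen; one six-membered non-aromatic ring with 2 hetero atoms) in place of a group of 7 heavy atoms (5 carbon, 2 nitrogen; one six-membered non-aromatic ring with 2 hetero atoms), on a carbonyl carbon. The 4-methylpiperazin-1-yl leaves, and the group that enters also has one six-membered non-aromatic ring with 2 hetero atoms.

Among the compounds with values here, only one measured step bears on this change. In that step, acetyl takes the place of methyl on an amine nitrogen in a ring, and compound 2 thereby also differs from compound 1 within the 4-methylpiperazin-1-yl. The size of that step, a 1.8-fold higher number from compound 1 to compound 2 (0.25 log units; within the scatter), stays within the scatter. It is a different change, so it is only weak guidance. No step beyond the scatter is therefore expected in this assay, and no direction can be argued with confidence.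

The estimate amounts to an expected 1.1-fold higher number from compound 1 to compound 3 (0.05 log units; within the scatter). For compound 3 the expected value is 10000 nM, with an estimated range from 4500 nM to 22000 nM.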

Compound 3, concentration for 50% growth inhibition: 6300 nM
Estimate against measurement, compound 3: 1.6-fold (0.20 log units) above, and the stated range covers the measured number.
By their numbers in this assay, from the lowest: compounds 3, 1 and 2 (each within the scatter of the next, the first and the last beyond it).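

In this assay, the group on this carbonyl carbon is now changed without touching the rest of the molecule, and putting the new ring group in place of the 4-methylpiperazin-1-yl gives a 1.4-fold lower number from compound 1 to compound 3 (0.15 log units; within the scatter). This place therefore takes the new group with no change that these numbers can resolve, which the earlier pair could not show, as it covered only a swap of methyl for acetyl on the ring nitrogen. Ring groups here can still be told apart, with a 2.5-fold lower number from compound 2 to compound 3 (0.40 log units; beyond the scatter) being the first step in this small series beyond the scatter, though a modest one, and nothing measured here offers an explanation for either step.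

On these data alone, all three compounds carry a six-membered non-aromatic ring with 2 hetero atoms on this carbonyl carbon, so it remains open how an open-chain group such as dimethylamino, or a ring bearing a carboxylic acid, would fare in the same place. It is also unknown whether these small differences in growth inhibition would hold in any cell line other than the one tested here.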